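This account rests on a few compounds, and the source may have more. Where it says the series, first, only, none or still open, it means among the compounds named here.

Measured in an ADME assay on MT4 cells (Homo sapiens) for cytotoxicity; a higher number here means that more compound is tolerated, a lower number that less compound is tolerated:
- compound 1 `O=C(CSc1snnc1-c1ccccc1)Nc1ccccc1F` gives > 361000 nM, which is a limit of the assay rather than a number.
- compound 2 `Cc1ccc(NC(=O)CSc2snnc2-c2ccc(Cl)cc2Cl)c(Br)c1` gives > 255000 nM, likewise a limit of the assay rather than a number.

Compound 2 thus stands only on a limit here; it sits at the limit of > 255000 nM in this assay, at which 1 of the 2 values shown sits. For the measured compounds named here, the one other value shown, for compound 1, is a limit as well, sitting at the limit of > 361000 nM in this assay, at which 1 of the 2 values shown sits. Neither compound was tolerated poorly enough for a number to appear.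

Compound 3 `O=C(CSc1snnc1-c1ccc(Cl)cc1Cl)Nc1ccccc1F` has not yet been measured. It differs from compound 2 by 2-fluorophenyl in place of 2-bromo-4-methylphenyl on an amide-type nitrogen. Going by the values given here, no measured pair of compounds differing in a single place exists, so the numbers give no direction for this step. Both measured compounds, carrying different groups on the amide nitrogen and on the shared core, reached only limits. In this assay, no step beyond the usual scatter is expected. Compound 3 is estimated at 300000 nM, with a range of 100000 nM to 1000000 nM, most likely again reported as a limit. This estimate means an expected step that the limit leaves unreadable from compound 2 to compound 3.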

Compound 3, half-maximal cytotoxic concentration: 19500 nM
Compound 3: the middle estimate sits 15-fold (1.19 log units) above what was measured; the whole stated range lies above it.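

In this assay, 2-fluorophenyl in place of 2-bromo-4-methylphenyl on an amide-type nitrogen gives an at least 13-fold lower number from compound 2 to compound 3 (1.11 log units; beyond the scatter), so the group at this place can strongly change how much compound the cells tolerate. With 2-fluorophenyl held fixed, 2,4-dichlorophenyl in place of phenyl on an aromatic carbon gives an at least 18-fold lower number from compound 1 to compound 3 (1.26 log units; beyond the scatter), so a second place matters too. For the compounds shown here, both steps are minimums: compound 1 and compound 2 each stand on a limit of the assay, not a number, and each carries only one of the two groups found together in compound 3.

Which part of the change at the nitrogen counts remains open: the fluorine, the loss of the bromine or the loss of the methyl. Also open, from the compounds shown here alone, is how an amine or a carboxylic acid at that place would fare.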